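Para substituent swap on the aryl piperazine of the series

The source may report more compounds than this note shows. Statements on the series, on what has been measured and on what is new or still open speak of the compounds shown alone.

Measured compounds in an assay on HEK293 cells for inhibition of Voltage-dependent T-type calcium channel subunit alpha-1G (Homo sapiens), read by fluorescence, tested at 10 uM; on this read-out lower numbers stand for less inhibition and higher numbers for more inhibition at the one concentration tested (going by the name of the read-out):
- compound 1 `CCCc1nc(-c2ccccc2)c(CNCCN2CCN(c3ccc(Cl)cc3)CC2)o1`: 55.8%
- compound 2 `CCCc1nc(-c2ccccc2)c(CNCCN2CCN(c3ccccc3OC)CC2)o1`: 39.7%
- compound 3 `CCCc1nc(-c2ccccc2)c(CNCCN2CCN(c3ccc(F)cc3)CC2)o1`: 54.1%

Compound 3 stands second highest of the three numbers in this assay. Its nearest neighbour is compound 1, with a number 1.7 percentage points lower from compound 1 to compound 3 (within the scatter) between them, so the two cannot be told apart. Compound 2 lies furthest away: a number 14.4 percentage points higher from compound 2 to compound 3 (beyond the scatter) marks a modest separation, and a number 16.1 percentage points lower from compound 1 to compound 2 (beyond the scatter) points the same way.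

The step to compound 4 `CCCc1nc(-c2ccccc2)c(CNCCN2CCN(c3ccc(C)cc3)CC2)o1` is methyl in place of fluoro on an aromatic carbon. The change sits on the aromatic carbon para to a large group of the ring on the amine nitrogen in a ring. For the measured compounds named here, the step that bears on it most directly is the one from compound 1 to compound 3, where fluoro in place of chloro on an aromatic carbon gave a number 1.7 percentage points lower from compound 1 to compound 3 (within the scatter), a difference inside the scatter. Going by the values given here, the only modest steps involve 2-methoxyphenyl, which is not touched here. A small group exchange on the same aromatic carbon is therefore expected to move this assay little, with no clear direction.

Compound 4 is estimated to give 52%, with a range of 38% to 66%. This amounts to an expected step of a number 2.1 percentage points lower from compound 3 to compound 4 (within the scatter), which would remain within the scatter.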

Compound 4, a percentage reported as inhibition, at one concentration (the size of the read-out at that concentration, not a potency): 48.1%
Compound 4: the middle estimate sits 3.9 percentage points above what was measured, and the stated range covers the measured number.
By their numbers in this assay, from the lowest: compounds 2, 4, 3 and 1 (each within the scatter of the next, the first and the last beyond it).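

In this assay, methyl on this aromatic carbon, para to a large group, stays within the scatter of both halogen compounds: a number 6 percentage points lower from compound 3 to compound 4 (within the scatter) and a number 7.7 percentage points lower from compound 1 to compound 4 (within the scatter). The place therefore accepts a carbon group as well as fluoro and chloro without a readable change, which widens what the fluoro and chloro pair alone could show. The 4-methylphenyl compound does not keep the separation from the 2-methoxyphenyl compound that both halogen compounds have, since a number 8.4 percentage points higher from compound 2 to compound 4 (within the scatter) lies within the scatter, so the modest gap seen earlier does not extend to every group at this place. Nothing available offers an explanation for these numbers.

As far as these compounds go, whether a larger or chemically different group on this carbon, such as a carboxylic acid, an amine or a nitrile, would move the number beyond the scatter remains open. The compounds shown also do not separate the effect of the methoxy group from that of its place on the ring in 2-methoxyphenyl, and a single tested concentration says nothing about potency across the series.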